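Removing a Core Methyl: From Compound 1 to Compound 4

This account rests on a few compounds, and the source may have more. Where it says the series, first, only, none or still open, it means among the compounds named here.

Measured compounds:
- compound 1 `Cc1cc(C)c2c(O)cc(-c3ccc4ccccc4c3)nc2n1`: 13500 nM
- compound 2 `Cc1cccc(-c2cc(O)c3c(C)cc(C)nc3n2)c1`: 38000 nM
- compound 3 `Cc1cccc(-c2cc(O)c3ccc(C)nc3n2)c1`: 97.7 nM

In a functional assay on cells (Tumor Cell line, Homo sapiens) for antiproliferative activity (on this read-out higher numbers stand for weaker inhibition of growth and lower numbers for stronger inhibition of growth), compound 1 gives 13500 nM, the second highest of the three numbers: compound 2 stands higher, and compound 3 stands far lower. Compound 4 `Cc1ccc2c(O)cc(-c3ccc4ccccc4c3)nc2n1` is not yet measured. Within the data shown here, it differs from compound 1 by a single change, (hydrogen in place of methyl on an aromatic carbon), on the shared core; compound 1 and compound 2 carry different aromatic groups on that core, but the methyl removed here sits at the same place as the one removed between compound 2 and compound 3. That one measured step bears directly on the question: a 390-fold lower number from compound 2 to compound 3 (2.59 log units; beyond the scatter). Among the measured compounds shown here, the same change is therefore expected to lower the number for compound 4 strongly in this assay, though with only one precedent the size remains uncertain. The expected step is a 270-fold lower number from compound 1 to compound 4 (2.43 log units; beyond the scatter). Compound 4 is estimated at 50 nM, with a likely range from 10 nM to 300 nM.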

Compound 4, concentration for 50% growth inhibition: 4570 nM
Estimate against measurement, compound 4: 91-fold (1.96 log units) below; measured number outside the range, above it.
By their numbers in this assay, from the lowest: compound 3; then compound 4; then compound 1; then compound 2.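

In this assay, taking away the methyl opposite the ring nitrogen gives a 3.0-fold lower number from compound 1 to compound 4 (0.47 log units; beyond the scatter), so the change again lowers the number, but only modestly. The earlier pair alone suggested a very large gain from this change, whereas the two pairs together show that its size differs sharply with the aromatic group carried by the shared core: the same change on two cores in this assay, a 390-fold lower number (2.59 log units; beyond the scatter) from compound 2 to compound 3 and a 3.0-fold lower number (0.47 log units; beyond the scatter) from compound 1 to compound 4, 130-fold (2.12 log units) apart, beyond the scatter of two such steps A step measured with one aromatic group is therefore a poor guide to its size with another, even when the direction is the same.

With only two aromatic groups shown, it remains open how the size of this step varies across other groups, and the data offer no reason for the gap. From the compounds shown here alone, it is also open how an ethyl group, a chlorine atom or an amine at this position would compare with hydrogen.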